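This account rests on a few compounds, and the source may have more. Where it says the series, first, only, none or still open, it means among the compounds named here.

- compound 1 `COc1ccc(Cn2c(N)nc3cc(Cl)c(Cl)cc32)cc1` gives 27000 nM
- compound 2 `Cc1ccc(Cn2c(N)nc3cc(Cl)c(Cl)cc32)cc1` gives 40000 nM
- compound 3 `CC(C)(C)c1ccc(Cn2c(N)nc3cc(Cl)c(Cl)cc32)cc1` gives 27000 nM

These values come from a functional assay on CEM-SS cells (Homo sapiens) for cytotoxicity; a higher number here means a weaker inhibitor, a lower number a stronger inhibitor. Compound 2, at 40000 nM, cannot be told apart from the other two, as a 1.5-fold higher number from compound 1 to compound 2 (0.17 log units; within the scatter) and a 1.5-fold lower number from compound 2 to compound 3 (0.17 log units; within the scatter) show. Compound 4 `Cc1ccc(Cn2c(Cl)nc3cc(Cl)c(Cl)cc32)cc1` differs from compound 2 by chloro in place of amino on an aromatic carbon.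

The measured steps, including no change at the digits printed from compound 1 to compound 3 (within the scatter), swap only methoxy, methyl and tert-butyl. Among the measured compounds shown here, none of them touches the amino, so no measured step shows what this change does. The value of compound 2, 40000 nM, is therefore the best guide, and no step beyond the scatter is expected in this assay, in either direction. The expected step is a 1.3-fold lower number from compound 2 to compound 4 (0.12 log units; within the scatter). For compound 4 the estimated value is 30000 nM, with an expected range of 10000 nM to 90000 nM.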

Compound 4, half-maximal inhibitory concentration: > 100000 nM
Compound 4 ended at the assay's limit; the forecaster's own chance of this, stated with the estimate: 20%; middle value at least 3.3-fold (0.52 log units) away from the limit.
By their numbers in this assay, from the lowest: compounds 1, 3 and 2 (each within the scatter of the next). At a limit, above all of these: compound 4.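

Swaps among methoxy, methyl and tert-butyl stayed within the scatter, but the group between two ring nitrogen atoms does change the read-out in this assay. Chloro in place of amino gives an at least 2.5-fold higher number from compound 2 to compound 4 (0.39 log units; beyond the scatter), so compound 2 is the stronger inhibitor of this pair. The size of that step is only a minimum, since compound 4 stands at a limit of the assay: the limit of > 100000 nM in this assay, at which 1 of the 4 values shown sits.

As far as these compounds go, how far above that limit compound 4 truly lies remains open. So does how a methylamine, a hydroxyl or a longer amine chain at this place would read.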